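Swapping the Pendant Ring and Cell Toxicity

A few compounds are considered here, and "the series" means these few. Any claim that something is new, unique, unknown or untested is made for them only; others in the source may bear on it.

Of the compounds shown here, three built on one shared core have been tested in an ADME assay on HEL cells (Homo sapiens) for cytotoxicity, with a stated time of 3 days; on this read-out higher numbers stand for lower toxicity in this test and lower numbers for higher toxicity in this test. Compound 1 `Cc1cc(-c2cccc(F)c2)c2ncc(CSCCc3ccccc3)n2c1` gives 20 ug/mL in this assay, and compound 3 `Cc1cc(-c2ccccc2)c2ncc(CSCCc3ccccc3)n2c1` gives 20 ug/mL. The step of no change at the digits printed from compound 1 to compound 3 (within the scatter) stays within the scatter. Compound 2 `Cc1cc(-c2cccc(C#N)c2)cn2c(CSCCc3ccccc3)cnc12` stands at the limit of > 100 ug/mL in this assay, at which 1 of the 3 values shown sits. In this assay compound 2 gives only a limit, > 100 ug/mL, not a number. Compound 4 `COc1ccc(-c2cc(C)c3ncc(CSCCc4ccccc4)n3c2)cc1` differs from compound 2 by 4-methoxyphenyl in place of 3-cyanophenyl on an aromatic carbon. Within the data shown here, no measured step covers this change; the one step seen was flat, and compound 2 sits at a limit while the others sit at a number. Compound 4 is therefore expected to land near 50 ug/mL, in a range from 20 ug/mL to 100 ug/mL. The estimated step of an at least 2.0-fold lower number from compound 2 to compound 4 (0.30 log units; that floor lies within the scatter) carries wide uncertainty.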

Compound 4, minimum cytotoxic concentration: 20 ug/mL
Beside the measured number, compound 4's estimate is 2.5-fold (0.40 log units) above it; the range from low to high includes it.
By their numbers in this assay, from the lowest: compounds 1, 3 and 4 (each within the scatter of the next). At a limit, above all of these: compound 2.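

Replacing 3-cyanophenyl with 4-methoxyphenyl on this aromatic carbon gives an at least 5.0-fold lower number from compound 2 to compound 4 (0.69 log units; beyond the scatter) in this assay, so the pendant group here can shift toxicity in this test. Among these compounds, the only earlier step, no change at the digits printed from compound 1 to compound 3 (within the scatter), was a smaller edit, fluoro to hydrogen, in compounds that carry the pendant ring elsewhere on the core. Only a floor can be given for the new step, as compound 2 gives a limit and not a number: the limit of > 100 ug/mL in this assay, at which 1 of the 4 values shown sits. The compounds shown cannot separate the loss of the nitrile from the gain of the methoxy group or from the shift in ring position. On these data alone, how a phenyl ring carrying an amine or a carboxylic acid would behave here also remains open.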